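Aryl replacement on the pyrazole core: compound 3 to compound 4

This account rests on a few compounds, and the source may have more. Where it says the series, first, only, none or still open, it means among the compounds named here.

Compound 3 `Cc1cc(-c2c(C)nn(-c3nc(-c4ccc(Cl)c(Cl)c4)c(SC(C)C)s3)c2C(=O)O)cc(C)n1` carries a 2,6-dimethylpyridin-4-yl group and gives the lowest number of the three measured compounds in a functional assay on BJAB cells (Homo sapiens) for antiproliferative activity, with a stated time of 4 days (a higher number here means that more compound is needed for the effect, a lower number that less compound is needed), with 580 nM. Compound 2 `Cc1nn(-c2nc(-c3ccc(Cl)c(Cl)c3)c(SC(C)C)s2)c(C(=O)O)c1-c1cc(C#N)cc(C(F)(F)F)c1` gives 3600 nM in this assay, and compound 1 `COc1cncc(-c2c(C)nn(-c3nc(-c4ccc(Cl)c(Cl)c4)c(SC(C)C)s3)c2C(=O)O)c1` gives 21000 nM. Both steps toward compound 3 are beyond the scatter: a 6.2-fold lower number from compound 2 to compound 3 (0.79 log units; beyond the scatter) and a 36-fold lower number from compound 1 to compound 3 (1.56 log units; beyond the scatter). The step between the two weaker compounds, a 5.8-fold lower number from compound 1 to compound 2 (0.77 log units; beyond the scatter), is modest.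

Compound 4 `Cc1nn(-c2nc(-c3ccc(Cl)c(Cl)c3)c(SC(C)C)s2)c(C(=O)O)c1-c1cccc(F)c1` differs from compound 3 at the same aryl position: 3-fluorophenyl in place of 2,6-dimethylpyridin-4-yl on an aromatic carbon. The two measured steps into compound 3 both replaced another aryl group with 2,6-dimethylpyridin-4-yl and both lowered the number, one modestly and one greatly. Every alternative aryl group measured so far gives a higher number than compound 3, though the carbon-only ring of compound 2 is closer to compound 3 than the pyridine of compound 1, so the ring type alone does not order the series. For compound 4 a modest rise in the number is therefore expected, the estimated step being a 4.3-fold higher number from compound 3 to compound 4 (0.63 log units; beyond the scatter). Compound 4 is estimated at 2500 nM, with a range from 800 nM to 8000 nM.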

Compound 4, half-maximal effective concentration: 900 nM
Beside the measured number, compound 4's estimate is 2.8-fold (0.44 log units) above it; low and high end bracket the measured number.
By their numbers in this assay, from the lowest: compounds 3 and 4 (each within the scatter of the next); then compound 2; then compound 1.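

In this assay the step reads a 1.6-fold higher number from compound 3 to compound 4 (0.19 log units; within the scatter) and so shows that this aromatic carbon of the shared core accepts a six-membered aromatic ring of carbon only as well as the 2,6-dimethylpyridin-4-yl group, with no difference that can be separated from the scatter. The further readings, a 4.0-fold lower number from compound 2 to compound 4 (0.60 log units; beyond the scatter) and a 23-fold lower number from compound 1 to compound 4 (1.37 log units; beyond the scatter), show that ring type does not set the number here: compound 2 and compound 4 both carry carbon-only rings yet stand apart beyond the scatter, so the groups on the ring count, and the pyridine rings of compound 1 and compound 3 likewise do not group together. Nothing measured here accounts for these differences.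

Open, from the compounds shown here alone, is whether an aromatic ring is needed at this position at all, and how a morpholine or a short alkyl chain on this carbon would compare with the 3-fluorophenyl group. Also open, going by these compounds, is whether a plain phenyl ring, or an amine or a carboxylic acid on the ring of compound 4, would move the number beyond the scatter.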